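A few compounds are considered here, and "the series" means these few. Any claim that something is new, unique, unknown or untested is made for them only; others in the source may bear on it.

Within the data shown here, compound 3, `O=S(=O)(NCCCNCc1ccc(C(F)(F)F)cc1)c1cc(C(F)(F)F)cc(C(F)(F)F)c1`, gives 3200 nM in a functional assay on PANC-1 cells (Homo sapiens) for inhibition, read by MTT assay, with a stated time of 72 h (on this read-out lower numbers stand for stronger inhibition of growth and higher numbers for weaker inhibition of growth), and carries the lowest of the three numbers measured so far. Compound 1, `O=S(=O)(NCCCNCc1ccc(Cl)c(Cl)c1)c1cc(C(F)(F)F)cc(C(F)(F)F)c1`, gives 5600 nM in this assay, and the step of a 1.8-fold lower number from compound 1 to compound 3 (0.24 log units; within the scatter) stays inside the scatter, so these two cannot be ranked against each other. Among the measured compounds shown here, compound 2, `COc1ccc(CNCCCNS(=O)(=O)c2cc(C(F)(F)F)cc(C(F)(F)F)c2)cc1OC`, gives 18000 nM in this assay, and the step of a 5.6-fold lower number from compound 2 to compound 3 (0.75 log units; beyond the scatter) is the one that sets compound 3 clearly apart; the step of a 3.2-fold higher number from compound 1 to compound 2 (0.51 log units; beyond the scatter) points the same way.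

Compound 4, `COc1ccc(CNCCCNS(=O)(=O)c2cc(C(F)(F)F)cc(C(F)(F)F)c2)cc1`, differs from compound 3 by one change: methoxy in place of trifluoromethyl on an aromatic carbon. For the measured compounds named here, two measured steps bear on it. Exchanging 3,4-dimethoxyphenyl for 4-(trifluoromethyl)phenyl or for 3,4-dichlorophenyl lowered the number in a 5.6-fold lower number from compound 2 to compound 3 (0.75 log units; beyond the scatter) and in the reverse reading of a 3.2-fold higher number from compound 1 to compound 2 (0.51 log units; beyond the scatter); the present change runs the other way, though it brings in a single methoxy rather than two. A higher number is therefore expected for compound 4 in this assay, of a size beyond the scatter but short of the whole step seen between compound 2 and compound 3. Compound 4 is estimated at 8000 nM, with a range from 3500 nM to 20000 nM. That estimate means an expected step of a 2.5-fold higher number from compound 3 to compound 4 (0.40 log units; beyond the scatter) in this assay.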

Compound 4, concentration for 50% growth inhibition: 11000 nM
Estimate against measurement, compound 4: 1.4-fold (0.14 log units) below; the measured number falls inside the stated range.
By their numbers in this assay, from the lowest: compounds 3, 1, 4 and 2 (each within the scatter of the next, the first and the last beyond it).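

The para site on the benzyl ring now stands on its own: with one group para to a large group and nothing else altered, methoxy in place of trifluoromethyl gives a step beyond the scatter in this assay (a 3.4-fold higher number from compound 3 to compound 4 (0.54 log units; beyond the scatter)). The earlier comparison of compound 2 with compound 3 could not show this, since two methoxy groups entered there at once. The second methoxy adds nothing that can be read (a 1.6-fold lower number from compound 2 to compound 4 (0.21 log units; within the scatter)), and compound 4 cannot be ranked against the dichloro compound (a 2.0-fold higher number from compound 1 to compound 4 (0.29 log units; within the scatter)), so in this small set a single methoxy at this place is enough to separate a compound from compound 3, while compound 1 is not separated from compound 3 or from compound 4. No measurement of any property of these groups is available to account for these steps.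

The compounds shown leave open where a fluorine, a nitrile or a plain unsubstituted phenyl at this place would fall relative to compound 3 and compound 4. They also leave open whether the same methoxy step would hold on a longer chain between the sulfonamide and the amine.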